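The compounds below may be only part of what the source reports. "The series", "measured", "known", "first", "only" and "open" are said of these compounds alone.

Measured so far in a functional assay on HeLa cells (Homo sapiens) for antiproliferative activity, read by MTT assay, with a stated time of 72 h; on this read-out lower numbers stand for stronger inhibition and higher numbers for weaker inhibition:
compound 1, `O=C(Nc1ccc(Cl)c(-c2nnc3c(Cl)cccn23)c1)c1ccc(C(F)(F)F)cc1Cl`, gives > 100000 nM, a limit of the assay.
compound 2, `Cc1nc(C(=O)Nc2ccc(Cl)c(-c3nnc4c(Cl)cccn34)c2)cs1`, gives 79800 nM.
compound 3, `CS(=O)(=O)c1ccc(C(=O)Nc2ccc(Cl)c(-c3nnc4c(Cl)cccn34)c2)c(Cl)c1`, gives > 100000 nM, a limit of the assay.

Compound 2 stands as the only numeric result in this assay; the other two compounds report only a limit, as the limit of > 100000 nM in this assay, at which 2 of the 3 values shown sit, records. Among the compounds with values here, the single measured step, a step that the two limits leave unreadable from compound 1 to compound 3, runs between two limits and so says nothing readable about the size or direction of a change at that position.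

Compound 4, `O=C(Nc1ccc(Cl)c(-c2nnc3c(Cl)cccn23)c1)c1ccon1`, differs from compound 2 by 1,2-oxazol-3-yl in place of 2-methyl-1,3-thiazol-4-yl on a carbonyl carbon. Within the data shown here, no measured step touches the group on the carbonyl carbon in a readable way; the one step at the amide end of the series is unreadable. No guidance on direction therefore exists beyond the measured value of compound 2 and the limit at which the other two sit.

The working expectation is that compound 4 stays near the value of compound 2, with the step of a 1.1-fold higher number from compound 2 to compound 4 (0.05 log units; within the scatter) expected to lie within the scatter and with a real chance that the assay returns only a limit. Compound 4 is estimated at 90000 nM, expected to fall between 25000 nM and 300000 nM.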

Compound 4, half-maximal inhibitory concentration: > 100000 nM
Compound 4 ended at the assay's limit; the forecaster's own chance of this, stated with the estimate: 55%; at least 1.1-fold (0.04 log units) between middle value and limit.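

In this assay, within the data shown here, 1,2-oxazol-3-yl in place of 2-methyl-1,3-thiazol-4-yl on a carbonyl carbon gives the first step at this end of the series that can be read at all, as an at least 1.2-fold higher number from compound 2 to compound 4 (0.09 log units; that floor lies within the scatter). The value of compound 4 is a limit of the assay, not a number. The floor of the step lies within the scatter, so no real difference between the two rings is established, and compound 2 remains the only compound in the series with a numeric result: the limit of > 100000 nM in this assay, at which 3 of the 4 values shown sit.

The compounds shown do not separate the contribution of the methyl group of compound 2 from that of its ring sulfur, since compound 4 differs from it in both. On these data alone, how a different kind of group on the carbonyl carbon, such as a short alkyl chain ending in a primary amine or a carboxylic acid, would read in this assay remains open, as does the effect of any change to the shared core.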